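Exchanging a Sulfur-Linked Ring for a Pyridinyloxy Group

The source may hold more compounds than are shown below. What is called first, only, known or untested is meant among the compounds shown, and "the series" means these compounds.

Compound 1 `CC(C)[C@H](NC(=O)COc1cccc2ccccc12)C(=O)N[C@@H](CC(=O)O)C(=O)CSC1=NCCS1` was tested in a functional assay on Jurkat cells (Homo sapiens) for inhibition; a lower number here means a stronger inhibitor, a higher number a weaker inhibitor. In this assay compound 1 returns > 200000 nM, which is a limit of the measurement rather than a number. Compound 4 `CC(C)[C@H](NC(=O)COc1cccc2ccccc12)C(=O)N[C@@H](CC(=O)O)C(=O)COc1ccccn1` differs from it in one place: a group of 7 heavy atoms (5 carbon, 1 nitrogen, 1 oxygen; one six-membered aromatic ring with 1 hetero atom) in place of a group of 6 heavy atoms (3 carbon, 1 nitrogen, 2 sulfur; one five-membered non-aromatic ring with 2 hetero atoms), on a saturated chain carbon bound to a carbonyl carbon. Two measured steps start from compound 1. Compound 2 `CC(C)[C@H](NC(=O)COc1cccc2ccccc12)C(=O)N[C@@H](CC(=O)O)C(=O)CSc1nc(-c2ccccc2)no1` gives 102000 nM, a change described as an at least 1.9-fold lower number from compound 1 to compound 2 (0.29 log units; that floor lies within the scatter). Compound 3 `CC(C)[C@H](NC(=O)COc1cccc2ccccc12)C(=O)N[C@@H](CC(=O)O)C(=O)COc1nc2ccccc2[nH]1` gives > 200000 nM, again a limit and not a number. The step that the two limits leave unreadable from compound 1 to compound 3 therefore cannot be sized, and two of the three values shown sit at the limit of > 200000 nM in this assay, at which 2 of the 3 values shown sit. For compound 4 the expectation is no step beyond the scatter, so the estimated change is a number no higher from compound 1 to compound 4 (the limit leaves the size open). Compound 4 is expected to give about 200000 nM, within 60000 nM to 500000 nM.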

Compound 4, half-maximal inhibitory concentration: > 200000 nM
Compound 4 gave a limit, no number; the forecaster's own chance of this, stated with the estimate: 65%; the middle value lies on the limit itself.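

In this assay, a single pyridine ring on oxygen at this saturated chain carbon also ends at the assay limit, so a third, smaller ring type joins the compounds that give no number: the limit of > 200000 nM in this assay, at which 3 of the 4 values shown sit. The one readable step is an at least 1.9-fold higher number from compound 2 to compound 4 (0.29 log units; that floor lies within the scatter), so this exchange is not shown to weaken inhibition beyond the scatter. The steps between limits cannot be read.

As far as these compounds go, how much each ring contributes stays open, since so few values are actual numbers. From the compounds shown here alone, whether an amine or a longer alkyl chain at this carbon would give a clearly lower number also stays open.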